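The compounds below may be only part of what the source reports. "The series", "measured", "known", "first", "only" and "open" are said of these compounds alone.

Measured in a functional assay on MDCK cells (Canis lupus familiaris) for inhibition; on this read-out higher numbers stand for lower toxicity in this test and lower numbers for higher toxicity in this test:
compound 1 `CC1O[C@]1(C)Cc1cc(=O)n(C)c(OC2CCCCC2)n1`: > 342000 nM, a limit
compound 2 `COc1nc(CC2(C)CCCO2)cc(=O)n1C`: 1620000 nM
compound 3 `CCCOc1nc(CC2(C)CCCO2)cc(=O)n1C`: 860000 nM

Among the measured compounds shown here, compound 3 lies within the scatter of compound 2, the only other exact number. Compound 4 `Cn1c(OC2CCCCC2)nc(CC2(C)CCCO2)cc1=O` is still unmeasured and differs from compound 3 by cyclohexyl in place of propyl on an oxygen on an aromatic ring, propoxy to cyclohexyloxy.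

For the measured compounds named here, the one measured step at this place is a 1.9-fold lower number from compound 2 to compound 3 (0.28 log units; within the scatter). Compound 1 also carries cyclohexyloxy, but it gives only a limit: the limit of > 342000 nM in this assay, at which 1 of the 3 values shown sits. With that single step inside the scatter, no clear change is expected in this assay, at most a small drift to a lower number. The expected change is a 1.4-fold lower number from compound 3 to compound 4 (0.16 log units; within the scatter). Compound 4 is estimated at 600000 nM, with an expected range of 250000 nM to 1400000 nM.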

Compound 4, half-maximal cytotoxic concentration: 816000 nM
Beside the measured number, compound 4's estimate is 1.4-fold (0.13 log units) below it; the range from low to high includes it.
By their numbers in this assay, from the lowest: compounds 4, 3 and 2 (each within the scatter of the next).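

In this assay, cyclohexyl in place of propyl on the oxygen on an aromatic ring gives a 1.1-fold lower number from compound 3 to compound 4 (0.02 log units; within the scatter), and cyclohexyl in place of methyl gives a 2.0-fold lower number from compound 2 to compound 4 (0.30 log units; within the scatter). A carbon ring at this place therefore leaves the read-out within the scatter, as the open chains did, so methyl, propyl and cyclohexyl cannot be told apart here. Compound 1 gives only a limit, and its step to compound 4 cannot be read: the limit of > 342000 nM in this assay, at which 1 of the 4 values shown sits.

Open, from the compounds shown here alone, is whether any group on this oxygen moves the number beyond the scatter, for example a phenyl, an amine or a carboxylic acid.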